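Aryl swap on the shared core: compound 3 to compound 4

A few compounds are considered here, and "the series" means these few. Any claim that something is new, unique, unknown or untested is made for them only; others in the source may bear on it.

Measured compounds:
compound 1, `Cc1ccc(S(=O)(=O)/C(=C/c2sccc2C)C(=O)c2ccc(Br)cc2)cc1`: 25000 nM
compound 2, `COc1ccccc1/C=C(\C(=O)c1ccc(Br)cc1)S(=O)(=O)c1ccc(C)cc1`: 1000 nM
compound 3, `Cc1ccc(S(=O)(=O)/C(=C/c2c[nH]c3ccccc23)C(=O)c2ccc(Br)cc2)cc1`: 10000 nM

In a functional assay on DU-145 cells (Homo sapiens) for inhibition, read by trypan blue exclusion, with a stated time of 96 h (on this read-out higher numbers stand for weaker inhibition of growth and lower numbers for stronger inhibition of growth), compound 3 gives 10000 nM, the second highest of the three numbers; its nearest neighbour is compound 1 and its furthest is compound 2, both steps beyond the scatter. Compound 4, `Cc1ccc(S(=O)(=O)/C(=C/c2ccc(F)cc2F)C(=O)c2ccc(Br)cc2)cc1`, has not been measured. Its change from compound 3 is 2,4-difluorophenyl in place of 1H-indol-3-yl on a double-bonded chain carbon bound to a double-bonded chain carbon.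

Going by the values given here, the steps that bear on this change all swap the group on the same double-bonded chain carbon. Against the 3-methylthiophen-2-yl of compound 1, the 1H-indol-3-yl of compound 3 gave a 2.5-fold lower number from compound 1 to compound 3 (0.40 log units; beyond the scatter), and against the 2-methoxyphenyl of compound 2 it gave a 10-fold higher number from compound 2 to compound 3 (1.00 log units; beyond the scatter). Among the compounds with values here, of the three groups tried, only one six-membered aromatic ring of carbon only has been seen, and it gave the lowest number. Compound 4 brings another such ring, though with fluorine rather than methoxy substitution, so the step of a 3.3-fold lower number from compound 3 to compound 4 (0.52 log units; beyond the scatter) is expected to be a lower number, beyond the scatter but short of compound 2. Compound 4 is thus estimated at 3000 nM in this assay, within 800 nM to 12000 nM.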

Compound 4, concentration for 50% growth inhibition: > 100000 nM
Compound 4 gave a limit, no number; the forecaster's own chance of this, stated with the estimate: 5%; at least 33-fold (1.52 log units) between middle value and limit.
By their numbers in this assay, from the lowest: compound 2; then compound 3; then compound 1. At a limit, above all of these: compound 4.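

Compound 4 sits at a limit of the assay, not at a number, in this assay: the limit of > 100000 nM in this assay, at which 1 of the 4 values shown sits. At this double-bonded chain carbon a six-membered aromatic ring of carbon only does not by itself give a low number: 2,4-difluorophenyl in place of 2-methoxyphenyl gives an at least 100-fold higher number from compound 2 to compound 4 (2.00 log units; beyond the scatter), so for this pair what the ring carries decides the read-out, not the ring alone. The same group also compares poorly with the two groups that contain a hetero atom, giving an at least 10-fold higher number from compound 3 to compound 4 (1.00 log units; beyond the scatter) and an at least 4.0-fold higher number from compound 1 to compound 4 (0.60 log units; beyond the scatter), so all three earlier groups give lower numbers than 2,4-difluorophenyl.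

As far as these compounds go, the true size of these steps stays open, since each is only a bound. Also open, from the compounds shown here alone, is how a phenyl ring carrying a single fluorine, a hydroxyl group or an amine would fall.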